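Trading a 4-chlorophenyl group for methyl on the shared core

A few compounds are considered here, and "the series" means these few. Any claim that something is new, unique, unknown or untested is made for them only; others in the source may bear on it.

Of the compounds shown here, three sharing one core have been tested in a functional assay on the whole organism (stomach) with Rattus norvegicus as the target; a lower number here means that less compound is needed, a higher number that more compound is needed for the effect. Compound 1, with structure `C/N=C(/NC#N)NCCCCn1nc(N(C)C)ccc1=O`, carries a dimethylamino group; in this assay compound 1 reaches only the limit > 100 mg/kg, so no number is known for it. Compound 2, `C/N=C(/NC#N)NCCCCn1nc(-c2ccc(C)cc2)ccc1=O`, carries a 4-methylphenyl group; in this assay compound 2 likewise reaches only the limit > 100 mg/kg. Going by the values given here, compound 3, `C/N=C(/NC#N)NCCCCn1nc(-c2ccc(Cl)cc2)ccc1=O`, carries a 4-chlorophenyl group, and in this assay compound 3 gives 100 mg/kg, the only actual number among the three. The step of a number no higher from compound 1 to compound 3 (the limit leaves the size open) and the step of a number no higher from compound 2 to compound 3 (the limit leaves the size open) both end at compound 3, but since they start from a limit their size cannot be read; the same holds for a step that the two limits leave unreadable from compound 1 to compound 2. Two of the three values sit at the limit of > 100 mg/kg in this assay, at which 2 of the 3 values shown sit.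

Compound 4, `C/N=C(/NC#N)NCCCCn1nc(C)ccc1=O`, is not yet measured. It differs from compound 3 by methyl in place of 4-chlorophenyl on an aromatic carbon. Among the compounds with values here, none of the measured steps exchanges an aromatic group for a methyl, so no step reads directly on this change. With compound 3 itself sitting at the edge of the measurable range, compound 4 is expected to land near that edge, with a real chance of reporting only a limit; the estimate for compound 4 in this assay is 150 mg/kg, with a range from 60 mg/kg to 400 mg/kg, which corresponds to the expected step of a 1.5-fold higher number from compound 3 to compound 4 (0.18 log units; within the scatter).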

Compound 4, dose for half-maximal effect: > 100 mg/kg
Compound 4: no number, only a limit; the forecaster's own chance of this, stated with the estimate: 55%; the middle value does not contradict the limit.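

In this assay, methyl in place of 4-chlorophenyl gives a number no lower from compound 3 to compound 4 (the limit leaves the size open) and so brings no readable gain at this aromatic carbon of the shared core. Only the 4-chlorophenyl group of compound 3 gives an actual number, while methyl in compound 4, the smallest of these groups, ends at a limit just as dimethylamino in compound 1 and 4-methylphenyl in compound 2 do, so group size alone does not sort these compounds. The steps that link two limits cannot be read, and most of the series now sits at the edge of what this test can report: the limit of > 100 mg/kg in this assay, at which 3 of the 4 values shown sit.

On these data alone, how far compound 4 lies beyond its limit, and so how large its step from compound 3 really is, stays unknown. Also open, as far as these compounds go, is whether a phenyl group with no substituent, or a carboxylic acid, on this aromatic carbon would need less compound in this assay than compound 3 does.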